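The source may report more compounds than this note shows. Statements on the series, on what has been measured and on what is new or still open speak of the compounds shown alone.

Measured compounds:
compound 1 `COc1c(Oc2ccnc(Nc3ccc(C#N)cc3)n2)ccc2cc(C#N)ccc12`: > 211000 nM
compound 2 `Cc1cnc(Nc2ccc(C#N)cc2)nc1Oc1ccc2cc(C#N)ccc2c1`: > 331000 nM

In an ADME assay on MT4 cells (Homo sapiens) for cytotoxicity, read by MTT assay, with a stated time of 4 days (on this read-out higher numbers stand for lower toxicity in this test and lower numbers for higher toxicity in this test), compound 1 gives > 211000 nM, a limit of the assay rather than a number. In this assay compound 2 gives > 331000 nM, likewise a limit of the assay. Both values shown in this assay are thus limits (the limit of > 211000 nM in this assay, at which 1 of the 2 values shown sits, (the limit of > 331000 nM in this assay, at which 1 of the 2 values shown sits)), and compound 2 stands at one of them; no order between compound 1 and compound 2 can be read from these two values, and no toxicity was reached for either within the tested range.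

Compound 3 `Cc1cnc(Nc2ccc(C#N)cc2)nc1Oc1ccc2cc(C#N)ccc2c1Br` is not yet measured. It differs from compound 2 by bromo in place of hydrogen on an aromatic carbon. Among the compounds with values here, no measured step of this kind exists, so there is nothing to set its size against; the expectation in this assay is a step of none beyond the scatter, with compound 3 again reported at or near the limit. The expected step from compound 2 to compound 3 is an at least 1.1-fold lower number from compound 2 to compound 3 (0.04 log units; that floor lies within the scatter). For compound 3 the estimate in this assay is 300000 nM, with a range from 100000 nM to 1000000 nM, and a limit rather than a number is the more likely report.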

Compound 3, half-maximal cytotoxic concentration: > 274000 nM
Compound 3: no number, only a limit (the forecaster's own chance of this, stated with the estimate: 70%); the middle value is on the limit's open side.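

In this assay compound 3 gives > 274000 nM, a limit of the assay. Compound 2 also stands at a limit, so no step can be read between compound 2 and compound 3. The compounds shown leave open whether bromo in place of hydrogen shifts the half-maximal cytotoxic concentration at all, and what that concentration is for any of them.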